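Acetyl in Place of Dimethylamino: Expected Cytotoxicity Shift

The source may report more compounds than this note shows. Statements on the series, on what has been measured and on what is new or still open speak of the compounds shown alone.

Of the compounds shown here, three have been measured in a functional assay on SW-620 cells (Homo sapiens) for cytotoxicity, read by sulforhodamine B assay, with a stated time of 48 h, tested at 0.01 uM; a lower number here means a stronger effect, a higher number a weaker effect of the compound at the concentration tested. Compound 1 `COc1cc(C)cc(-c2c(-c3ccnc(-c4ccc(N(C)C)cc4)c3)cnn2CC#N)c1` gives 69% in this assay. Compound 2 `Cc1cc(O)cc(-c2nn(CC#N)cc2-c2ccnc(-c3ccc(Oc4ccccc4)cc3)c2)c1` gives 88%, and compound 3 `COc1cc(C)cc(-c2nn(CC#N)cc2-c2ccc(-c3cccc(C(C)=O)c3)nc2)c1` gives 91%. Compound 1 stands lowest of the three numbers, which means the strongest effect at the tested concentration; its nearest neighbour is compound 2, whose number lies beyond the scatter above it, and compound 3 lies further still, also beyond the scatter.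

Compound 4 `COc1cc(C)cc(-c2c(-c3ccnc(-c4ccc(C(C)=O)cc4)c3)cnn2CC#N)c1` has not yet been measured. It differs from compound 1 in one place: acetyl in place of dimethylamino on an aromatic carbon. Going by the values given here, no measured pair shows this change on its own, so the size of the step can only be expected, not read off. Compound 3 carries an acetyl group at a different place and gives 91%, the highest number of the three. On that basis compound 4 is expected to show a somewhat weaker effect than compound 1, with a step of a number 9 percentage points higher from compound 1 to compound 4 (within the scatter) toward a higher number that may be modest and could fall within the scatter. The estimate for compound 4 is 78%, with a range from 62% to 95%.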

Compound 4, a percentage reported as activity, at one concentration (the size of the read-out at that concentration, not a potency): 88%
For compound 4 the middle estimate is 10 percentage points below the measured one; the range from low to high includes it.
By their numbers in this assay, from the lowest: compound 1; then compounds 2, 4 and 3 (each within the scatter of the next).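

In this assay, the change from 4-(dimethylamino)phenyl to 4-acetylphenyl, with the rest of the molecule held constant, gives a number 19 percentage points higher from compound 1 to compound 4 (beyond the scatter) and so shows that this position para to a large group affects the read-out. The two groups match in heavy-atom count and in hydrogen-bond donors and acceptors, so those counts do not separate a dimethylamino compound from an acetyl compound here. No available measurement accounts for the step.

On these data alone, what remains open is whether the lower number belongs to dimethylamino specifically or would also appear with another group at this position, such as a primary amine, a methoxy group or a carboxylic acid. A single concentration also leaves open how the two compounds differ in potency.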